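Working notes on three measured compounds and one pending

The source may hold more compounds than are shown below. What is called first, only, known or untested is meant among the compounds shown, and "the series" means these compounds.

Measured so far in a functional assay on the whole organism for inhibition, with Mus musculus as the target, at a dose of 10 mg/kg; a lower number here means less inhibition, a higher number more inhibition at the dose given (going by the name of the read-out):
compound 1, `O=COCC1=CS(=O)(=O)c2ccccc2C1=O`, gives 91.6%;
compound 2, `CCC(=O)OCC1=CS(=O)(=O)c2ccccc2C1=O`, gives 99.5%;
compound 3, `O=C1C(CI)=CS(=O)(=O)c2ccccc21`, gives 98%.

Compound 3 stands second highest of the three numbers. Its nearest neighbour is compound 2 and its furthest is compound 1; the steps between them ran a number 1.5 percentage points lower from compound 2 to compound 3 (within the scatter) and a number 6.4 percentage points higher from compound 1 to compound 3 (within the scatter), both within the scatter. Compound 4, `CCNC(=O)OCC1=CS(=O)(=O)c2ccccc2C1=O`, differs from compound 3 by (ethylcarbamoyl)oxy in place of iodo on a saturated chain carbon bound to a double-bonded ring carbon. The two steps above are the ones that bear on this change, since each replaced an oxygen-linked group at the same saturated chain carbon with iodo without any shift beyond the scatter. Restoring an oxygen-linked group is therefore expected to give no step beyond the scatter, a number 2 percentage points lower from compound 3 to compound 4 (within the scatter). Compound 4 is estimated at 96%, within 85% to 100%.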

Compound 4, a percentage reported as inhibition, in the whole organism at one dose (the size of the read-out at that dose, not a potency): 99.3%
Compound 4: middle estimate off by 3.3 percentage points, on the low side; low and high end bracket the measured number.
By their numbers in this assay, from the lowest: compounds 1, 3, 4 and 2 (each within the scatter of the next).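

At the saturated chain carbon bound to a double-bonded ring carbon, a group holding nitrogen and a hydrogen-bond donor now gives a step no larger than the scatter in this assay, with (ethylcarbamoyl)oxy in place of iodo reading a number 1.3 percentage points higher from compound 3 to compound 4 (within the scatter) on this change. Ethylamino on a carbonyl carbon likewise gives no step beyond the scatter, reading a number 0.2 percentage points lower from compound 2 to compound 4 (within the scatter) in place of ethyl and a number 7.7 percentage points higher from compound 1 to compound 4 (within the scatter) in place of hydrogen. Nothing available explains these readings.

Still open, from the compounds shown here alone, is whether a longer chain in place of ethylamino on a carbonyl carbon, or a carboxylic acid or an amine on the saturated chain carbon, would give a step beyond the scatter.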